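Cyclopropyl in place of isopropyl: notes on compound 4

A few compounds are considered here, and "the series" means these few. Any claim that something is new, unique, unknown or untested is made for them only; others in the source may bear on it.

Of the compounds shown here, three sharing one side of the molecule have been measured in a functional assay on OCI-Ly3 cells (Homo sapiens) for antiproliferative activity (a higher number here means that more compound is needed for the effect, a lower number that less compound is needed), so far. Compound 1 `CC(C)c1ncncc1NC(=O)Nc1cnc(-n2nccn2)c(Cl)c1` gives > 20000 nM and this is a limit of the assay and not a number. Compound 2 `Cc1c(NC(=O)Nc2cnc(-n3nccn3)c(Cl)c2)cnc2ccc(Br)cc12` gives 12900 nM in this assay while compound 3 `CC(C)c1c(NC(=O)Nc2cnc(-n3nccn3)c(Cl)c2)cnc2ccccc12` gives 2420 nM as the lowest of the numbers in hand. The gap between compound 2 and compound 3 lies beyond the scatter, which makes compound 3 the natural reference point for the next comparison.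

Compound 4 `O=C(Nc1cnc(-n2nccn2)c(Cl)c1)Nc1cnc2ccccc2c1C1CC1` carries cyclopropyl in place of the isopropyl of compound 3 on an aromatic carbon opposite the ring nitrogen cyclopropyl in place of isopropyl on an aromatic carbon and is otherwise the same. Going by the values given here, no measured pair differs in one place only, so the expectation rests on compound 3 at 2420 nM and on the structural change alone. A small move towards a higher number is expected, and the expected step of a 1.4-fold higher number from compound 3 to compound 4 (0.16 log units; within the scatter) stays close to the scatter. In this assay the estimated value for compound 4 is 3500 nM with an expected range from 1300 nM to 9500 nM around it.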

Compound 4, half-maximal effective concentration: 1580 nM
Compound 4: middle estimate off by 2.2-fold (0.35 log units), on the high side, and the stated range covers the measured number.
By their numbers in this assay, from the lowest: compounds 4 and 3 (each within the scatter of the next); then compound 2. At a limit, above all of these: compound 1.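

Going by these compounds alone, this is the first step that changes one place only, and it concerns the carbon opposite the ring nitrogen, in the ring fused to its neighbour. In this assay the change to cyclopropyl in place of isopropyl gives a 1.5-fold lower number from compound 3 to compound 4 (0.19 log units; within the scatter), so compounds 3 and 4 stand level and the new three-membered ring, at an unchanged count of heavy atoms, leaves no readable mark on the number at this position. Nothing in hand bears on a cause for this outcome, and a result within the scatter calls for none.

The compounds shown leave open how this position responds to a group that carries something other than carbon, such as an amine or a methoxy group, and to a longer chain such as n-butyl. From the compounds shown here alone, the reading also rests on a single pair in one assay, so whether the same exchange stays as quiet on another core, or with the chloro and triazole side of the molecule changed, remains open.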